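This account rests on a few compounds, and the source may have more. Where it says the series, first, only, none or still open, it means among the compounds named here.

Of the compounds shown here, two built on one shared core have so far been tested in a functional assay on A549 cells (Homo sapiens) for cytotoxicity, read by MTT assay, with a stated time of 72 h; on this read-out lower numbers stand for an effect already at smaller amounts and higher numbers for an effect only at larger amounts of compound. The first is compound 1, with the structure `CCc1cccc2c(OC)c(-c3occ(C)c3C(=O)NC)ccc12`. In this assay compound 1 gives only a limit, > 10 ug/mL, and not a number. The second is compound 2, with the structure `CCc1cccc2c(OC(C)=O)c(-c3occ(C)c3COC(C)=O)ccc12`. In this assay compound 2 likewise gives only a limit, > 10 ug/mL. Where compound 2 stands on the numbers shown is therefore simple: it sits at the limit of > 10 ug/mL in this assay, at which 2 of the 2 values shown sit, so nothing separates it from compound 1, and no step between measured compounds can be counted.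

Compound 3, with the structure `CCOc1c(-c2occ(C)c2COC(C)=O)ccc2c(CC)cccc12`, has not yet been measured. It differs from compound 2 in one place: ethyl in place of acetyl on an oxygen on an aromatic ring. Among the measured compounds shown here, no measured step shows what such a change does here. The expected step is a step that the limit leaves unreadable from compound 2 to compound 3, none beyond the scatter. Compound 3 is thus expected to give about 15 ug/mL, within a range from 5 ug/mL to 60 ug/mL, and most likely once more only a limit.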

Compound 3, concentration for half-maximal effect: > 10 ug/mL
Compound 3 gave a limit, no number; the forecaster's own chance of this, stated with the estimate: 80%; the middle value is on the limit's open side.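

Compound 3, like compound 2, gives only a limit in this assay, so no step can be read between these two compounds: the limit of > 10 ug/mL in this assay, at which 3 of the 3 values shown sit.

The compounds shown leave open what ethyl in place of acetyl on an oxygen on an aromatic ring does in this assay, and which change to the shared core, if any, would give a number instead of a limit.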